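Chloro to hydrogen on the pendant phenyl ring

A few compounds are considered here, and "the series" means these few. Any claim that something is new, unique, unknown or untested is made for them only; others in the source may bear on it.

Measured compounds:
compound 1 `C=C(Br)C(=O)Nc1cccc(-c2cn3nc(Cc4ccccc4)sc3n2)c1` gives 3000 nM
compound 2 `C=C(Br)C(=O)Nc1cccc(-c2cn3nc(Cc4ccc(Cl)cc4)sc3n2)c1` gives 2300 nM
compound 3 `Nc1cccc(-c2cn3c(-c4ccc(Cl)cc4)csc3n2)c1` gives 22000 nM

Compound 4 `Nc1cccc(-c2cn3c(-c4ccccc4)csc3n2)c1` is not yet measured. In a functional assay on L1210 cells (Mus musculus) for inhibition, read by cell counting, with a stated time of 2 days (on this read-out lower numbers stand for stronger inhibition and higher numbers for weaker inhibition), compound 2 and compound 1 differ by one change, (hydrogen in place of chloro on an aromatic carbon), and this change made a step of a 1.3-fold higher number from compound 2 to compound 1 (0.12 log units; within the scatter). Compound 3 stands apart in this assay, with the highest number of the three; the difference between the core of compound 3 and the core of compound 2 is not broken down here. The change from compound 3 to compound 4 is hydrogen in place of chloro on an aromatic carbon, the same change at the same place as before. The step from compound 3 to compound 4 is expected to be a 1.2-fold higher number from compound 3 to compound 4 (0.07 log units; within the scatter), resting on the earlier step of a 1.3-fold higher number from compound 2 to compound 1 (0.12 log units; within the scatter). Compound 4 is accordingly estimated at 26000 nM, with a range of 12000 nM to 55000 nM.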

Compound 4, half-maximal inhibitory concentration: 85000 nM
The estimate for compound 4 lay 3.3-fold (0.51 log units) below the measured number, outside the stated range (above it).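

In this assay the change from 4-chlorophenyl to phenyl gave a 3.9-fold higher number from compound 3 to compound 4 (0.59 log units; beyond the scatter). The size of this step did not carry over from one core to the other: the same change on two cores in this assay, a 1.3-fold higher number (0.12 log units; within the scatter) from compound 2 to compound 1 and a 3.9-fold higher number (0.59 log units; beyond the scatter) from compound 3 to compound 4, 3.0-fold (0.47 log units) apart, beyond the scatter of two such steps. Among these compounds, with only two pairs, which differ from each other in more than one place, this shows that the step cannot be assumed to transfer unchanged, but it does not show which structural difference sets the gap.

As far as these compounds go, it remains open whether a fluoro, methyl or methoxy group at this position would follow the chloro on either core. Also open, from the compounds shown here alone, is how the chloro to hydrogen step would behave on a further core.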